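Urea aryl variation on the shared core

The source may report more compounds than this note shows. Statements on the series, on what has been measured and on what is new or still open speak of the compounds shown alone.

In a functional assay on BaF3 cells (Mus musculus) for inhibition, read by MTT assay, with a stated time of 3 days (on this read-out lower numbers stand for stronger inhibition of growth and higher numbers for weaker inhibition of growth), compound 1 `O=C(Nc1ccc(Br)cc1)Nc1ccc(Nc2ncnc3c2OCCN3)cc1` gives 10000 nM. Compound 2 `O=C(Nc1ccc(Nc2ncnc3c2OCCN3)cc1)Nc1ccc(C(F)(F)F)cc1` gives 10000 nM, and the step of no change at the digits printed from compound 1 to compound 2 (within the scatter). For compound 3 `COc1cccc(NC(=O)Nc2ccc(Nc3ncnc4c3OCCN4)cc2)c1` only a limit is reported, > 10000 nM. Accordingly a number no lower from compound 1 to compound 3 (the limit leaves the size open), and the limit of > 10000 nM in this assay, at which 1 of the 3 values shown sits, marks where compound 3 sits. Compound 1 thus stands level with compound 2, with compound 3 no lower. Compound 4 `O=C(Nc1ccc(Nc2ncnc3c2OCCN3)cc1)Nc1cc(Cl)cc(Cl)c1` differs from compound 1 by 3,5-dichlorophenyl in place of 4-bromophenyl on an amide-type nitrogen. Within the data shown here, the steps that bear on this change, no change at the digits printed from compound 1 to compound 2 (within the scatter) and a number no lower from compound 1 to compound 3 (the limit leaves the size open), show no gain for trifluoromethyl or 3-methoxyphenyl, so no step beyond the scatter is expected in this assay. Compound 4 is expected to give 10000 nM, with a range of 4000 nM to 20000 nM. The expected step is no change at the digits printed from compound 1 to compound 4 (within the scatter).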

Compound 4, concentration for 50% growth inhibition: 10000 nM
Compound 4: the middle estimate sits on the measured number at the digits printed; low and high end bracket the measured number.
By their numbers in this assay, from the lowest: compounds 1, 2 and 4 (each within the scatter of the next).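

In this assay, 3,5-dichlorophenyl on the amide-type nitrogen extends the comparison from singly substituted aryl groups to one carrying two chlorines, and the read-out gives no change at the digits printed from compound 1 to compound 4 (within the scatter), no change at the digits printed from compound 2 to compound 4 (within the scatter) and a number no higher from compound 3 to compound 4 (the limit leaves the size open). Among compounds 1, 2 and 4, swapping the aryl group at this position therefore brings no step beyond the scatter. Compound 3 is reported only as a limit: the limit of > 10000 nM in this assay, at which 1 of the 4 values shown sits.

Going by these compounds, whether an amine or a carboxylic acid on this aryl ring would shift the number stays open. So does the effect of a longer alkyl chain in place of the aryl group.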